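The source may hold more compounds than are shown below. What is called first, only, known or untested is meant among the compounds shown, and "the series" means these compounds.

Measured so far in a functional assay on DU-145 cells (Homo sapiens) for inhibition, read by trypan blue exclusion, with a stated time of 96 h; on this read-out higher numbers stand for weaker inhibition of growth and lower numbers for stronger inhibition of growth:
- Compound 1 `O=C(O)c1ccc(C(=O)/C(=C\c2ccc(F)c([N+](=O)[O-])c2)SCc2ccc(F)cc2)cc1`: 1000 nM
- Compound 2 `O=C(O)c1ccc(C(=O)/C(=C\c2ccc(O)c([N+](=O)[O-])c2)SCc2ccc(F)cc2)cc1`: > 100000 nM

Compound 2 gives > 100000 nM, which is a limit of the assay and not a number. This places compound 2 at the limit of > 100000 nM in this assay, at which 1 of the 2 values shown sits.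

The next compound, compound 3 `COc1ccc(/C=C(/SCc2ccc(F)cc2)C(=O)c2ccc(C(=O)O)cc2)cc1O`, keeps the shared core but changes one aromatic group: 3-hydroxy-4-methoxyphenyl in place of 4-hydroxy-3-nitrophenyl on a double-bonded chain carbon bound to a double-bonded chain carbon. In words, this is 3-hydroxy-4-methoxyphenyl in place of 4-hydroxy-3-nitrophenyl on a double-bonded chain carbon bound to a double-bonded chain carbon.

Going by the values given here, only one measured step bears on this change: an at least 100-fold higher number from compound 1 to compound 2 (2.00 log units; beyond the scatter). It was a large step, made within the same aromatic group, so a change in this group can shift the read-out strongly. Among the compounds with values here, it is only a partial guide, as compound 3 keeps a hydroxy group but loses the nitro group, and no measured step covers that exchange. A large move towards stronger inhibition of growth is therefore expected, although a second result at the limit remains possible.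

The estimated step is an at least 20-fold lower number from compound 2 to compound 3 (1.30 log units; beyond the scatter). For compound 3, the estimated value is 5000 nM, with an expected range of 500 nM to 50000 nM.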

Compound 3, concentration for 50% growth inhibition: 10000 nM
Compound 3: the middle estimate sits 2.0-fold (0.30 log units) below what was measured; measured number inside the range.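

Exchanging 4-hydroxy-3-nitrophenyl for 3-hydroxy-4-methoxyphenyl on the double-bonded chain carbon brings growth inhibition in this assay back to a measurable level (an at least 10-fold lower number from compound 2 to compound 3 (1.00 log units; beyond the scatter)), so carrying a hydroxy group does not by itself leave this aromatic group at the limit. The recovery is only partial, as the 4-fluoro-3-nitrophenyl group still gives the stronger inhibition of the two (a 10-fold higher number from compound 1 to compound 3 (1.00 log units; beyond the scatter)), and compound 1 remains the strongest of the three compounds. The first of these steps gives only a minimum size, since compound 2 sits at a limit of the assay and not at a number: the limit of > 100000 nM in this assay, at which 1 of the 3 values shown sits.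

Compound 3 differs from compound 2 in three ways at once, with the nitro group gone, a methoxy group added and the hydroxy group at a different ring position, so the compounds shown cannot say which of these accounts for the step. On these data alone, it also remains open how this position would respond to an amine or a chlorine atom in place of the fluoro of 4-fluoro-3-nitrophenyl.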